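The source may report more compounds than this note shows. Statements on the series, on what has been measured and on what is new or still open speak of the compounds shown alone.

Of the compounds shown here, three have been measured in a physicochemical assay for lipophilicity, read by HPLC, measured as octanol-water partition; on this read-out lower numbers stand for lower lipophilicity and higher numbers for higher lipophilicity. Compound 1, `CC(C)(C)OC(=O)NCC(=O)OCC(=O)NCCC[Te]c1ccccc1`, gives 3.83; compound 3, `CC1=C(SCCC(=O)OCC(=O)NCCC[Te]c2ccccc2)C(=O)c2ccccc2C1=O`, gives 3.8; and compound 2, `COc1ccc(N(CC(=O)NCCC[Se]c2ccccc2)C(=O)c2ccccc2)cc1`, gives 3.1. On these three numbers compound 2 stands lowest, with compound 3 nearest and compound 1 furthest, both separated from it by more than the usual scatter.

The step under consideration leads from compound 2 to compound 4, `COc1ccc(N(CC(=O)NCCC[Se]c2ccccc2)C(=O)/C=C/c2ccccc2)cc1`, which has not yet been measured in this assay. The change is a single one: 2-phenylethenyl in place of phenyl on a carbonyl carbon. Cut one bond further out, it reads benzoyl to (2-phenylethenyl)carbonyl, so the amide-type nitrogen and everything beyond it stay as they are.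

For the measured compounds named here, no measured pair in this set shares this change, so the expectation rests on the change itself, which adds two carbon atoms and one double bond outside aromatic rings and removes nothing polar. For compound 4 the expected step in this assay is a number 0.60 log units higher from compound 2 to compound 4 (beyond the scatter), an upward move somewhat beyond the scatter. Compound 4 is therefore estimated at 3.7, with a likely range from 3.3 to 4.1.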

Compound 4, partition coefficient: 3.7
Compound 4: the middle estimate sits on the measured number at the digits printed, and the stated range covers the measured number.
By their numbers in this assay, from the lowest: compound 2; then compounds 4, 3 and 1 (each within the scatter of the next).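

In this assay, for the compounds shown here, replacing phenyl with 2-phenylethenyl on a carbonyl carbon gives a number 0.60 log units higher from compound 2 to compound 4 (beyond the scatter), the only reading here of a single change at one place. The amide-type nitrogen and the rest of the compound stay the same, and both groups contain carbon only, with no hydrogen-bond donors or acceptors, so this step isolates a carbon-only swap at this position. Nothing shown explains the size of the step.

From the compounds shown here alone, it remains open whether the double bond matters on its own, which 2-phenylethyl at this carbonyl carbon would test. Also open, going by these compounds, are how a phenyl group carrying an amine or a carboxylic acid would read here and whether the same swap would give a similar step on a different core.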